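Hydrazone aryl variation: bromo-hydroxyphenyl analogue of compound 2

The source may hold more compounds than are shown below. What is called first, only, known or untested is meant among the compounds shown, and "the series" means these compounds.

Two measured members of the series share one core and differ only in the aryl group on the hydrazone carbon. Compound 1 `Cc1c(C(=O)N/N=C\c2ccc(O)cc2O)oc2cccc(O)c12` gives 14800 nM in a functional assay on PC-3 cells (Homo sapiens) for inhibition; on this read-out higher numbers stand for weaker inhibition and lower numbers for stronger inhibition. Compound 2 `COc1cccc(/C=N\NC(=O)c2oc3cccc(O)c3c2C)c1` reaches only a limit of the assay, reported as >= 40000 nM in this assay. The step of an at least 2.7-fold higher number from compound 1 to compound 2 (0.43 log units; beyond the scatter) thus places compound 2 at the weak end of the numbers shown, and the limit of >= 40000 nM in this assay, at which 1 of the 2 values shown sits, marks where its value sits.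

Compound 3 `Cc1c(C(=O)N/N=C\c2cccc(Br)c2O)oc2cccc(O)c12` differs from compound 2 in one place: 3-bromo-2-hydroxyphenyl in place of 3-methoxyphenyl on a carbon with a double bond to nitrogen. Among the measured compounds shown here, the only measured step that bears on this change is an at least 2.7-fold higher number from compound 1 to compound 2 (0.43 log units; beyond the scatter), which ran the opposite way, from an aryl ring carrying hydroxyl groups to one without, and lost inhibition beyond the scatter. Restoring a hydroxyl, now accompanied by bromine, is expected to recover part of that loss. For compound 3 a step of an at least 2.0-fold lower number from compound 2 to compound 3 (0.30 log units; that floor lies within the scatter) toward stronger inhibition is expected in this assay. Compound 3 is estimated at 20000 nM, within 8000 nM to 45000 nM, with a fair chance that the assay again reports only a limit.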

Compound 3, half-maximal inhibitory concentration: 16600 nM
For compound 3 the middle estimate is 1.2-fold (0.08 log units) above the measured one; measured number inside the range.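

Exchanging the methoxy-bearing ring for the ring that carries bromine and a hydroxyl gives an at least 2.4-fold lower number from compound 2 to compound 3 (0.38 log units; beyond the scatter) in this assay, so the weak reading of compound 2 does not hold for every change at this position. Between the 2,4-dihydroxyphenyl and 3-bromo-2-hydroxyphenyl groups there is a 1.1-fold higher number from compound 1 to compound 3 (0.05 log units; within the scatter), so no difference can be claimed between these two rings, and among the compounds shown both hydroxyl-bearing rings read alike while the ring without a hydroxyl stands apart, with no compound against this pattern. The value for compound 2 is a limit, so the gain from that compound is a floor and not a measured size:
the limit of >= 40000 nM in this assay, at which 1 of the 3 values shown sits.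

As far as these compounds go, it remains open how much of the gain belongs to the hydroxyl and how much to the bromine, a question that a plain 2-hydroxyphenyl group on the same carbon would address. From the compounds shown here alone, it is also open whether an aminophenyl or carboxyphenyl group at this position would read differently from the hydroxyl-bearing rings, or whether the series stays in this range of numbers.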